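From 4-chlorobenzyl to 2-bromobenzyl: working notes

The source may report more compounds than this note shows. Statements on the series, on what has been measured and on what is new or still open speak of the compounds shown alone.

Measured in a functional assay on A-375 cells (Homo sapiens) for antiproliferative activity, read by MTT assay, with a stated time of 24 h (on this read-out higher numbers stand for weaker inhibition and lower numbers for stronger inhibition), so far:
- compound 1 `C=CCOc1ccc2c(=O)c(-c3cc(OC)c(OC)cc3OC)coc2c1` gives 4750 nM
- compound 2 `C#CCOc1ccc2c(=O)c(-c3cc(OC)c(OC)cc3OC)coc2c1` gives 3680 nM
- compound 3 `COc1cc(OC)c(-c2coc3cc(OCc4ccc(Cl)cc4)ccc3c2=O)cc1OC` gives 1020 nM

Compound 3 stands lowest of the three at 1020 nM and both steps to it lie beyond the scatter (a 4.7-fold lower number from compound 1 to compound 3 (0.67 log units; beyond the scatter) and a 3.6-fold lower number from compound 2 to compound 3 (0.56 log units; beyond the scatter)). The vinyl and ethynyl compounds do not separate (a 1.3-fold lower number from compound 1 to compound 2 (0.11 log units; within the scatter)).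

The next case is compound 4 `COc1cc(OC)c(-c2coc3cc(OCc4ccccc4Br)ccc3c2=O)cc1OC` which differs from compound 3 by one change (2-bromophenyl in place of 4-chlorophenyl on a saturated chain carbon bound to an oxygen on an aromatic ring). The two steps into compound 3 are the nearest evidence. Both are modest, and both put 4-chlorophenyl in place of vinyl or ethynyl. Compound 4 keeps a substituted phenyl at that place, so most of that gain should hold. Going by the values given here, no measured step changes the halogen or where it sits on the phenyl, so this change has no direct measure. A small step is expected in this assay (a 1.4-fold higher number from compound 3 to compound 4 (0.14 log units; within the scatter)) and none beyond the scatter, with a slight lean to a higher number. Losing the whole gain would bring it back to the level of compound 2 at 3680 nM and that is taken as the outer edge. For compound 4 the estimate is 1400 nM (expected range 600 nM to 3300 nM).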

Compound 4, half-maximal inhibitory concentration: 2850 nM
Estimate against measurement, compound 4: 2.0-fold (0.31 log units) below, and the stated range covers the measured number.
By their numbers in this assay, from the lowest: compound 3; then compounds 4, 2 and 1 (each within the scatter of the next).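

In this assay, going by these compounds alone, a halogen-bearing phenyl at this place does not by itself keep the low number of compound 3: the change of 4-chlorophenyl to 2-bromophenyl gives a 2.8-fold higher number from compound 3 to compound 4 (0.45 log units; beyond the scatter) and is the first measured step in which a phenyl stays on the saturated chain carbon bound to an oxygen on an aromatic ring while the halogen and where it sits both change. The 2-bromophenyl group also does not separate from the two small groups, with a 1.3-fold lower number from compound 2 to compound 4 (0.11 log units; within the scatter) against the ethynyl compound and a 1.7-fold lower number from compound 1 to compound 4 (0.22 log units; within the scatter) against the vinyl compound, so among the groups shown only 4-chlorophenyl stands apart from the rest in this assay. Nothing measured on these compounds bears on why the step has this size.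

The step changes the halogen and its place together, so the compounds shown do not tell which of the two carries it. Also open, as far as these compounds go, is how an unsubstituted phenyl would read at this place, and whether an amine or a carboxylic acid on a longer chain would be tolerated there.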